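A few compounds are considered here, and "the series" means these few. Any claim that something is new, unique, unknown or untested is made for them only; others in the source may bear on it.

Compound 1 `O=C(N/N=C\c1cccc(O)c1)Nc1nnc(COc2ccc3ccccc3c2)o1`: 300 mg/kg
Compound 2 `O=C(N/N=C\c1ccccc1)Nc1nnc(COc2ccc3ccccc3c2)o1`: 300 mg/kg

In a functional assay on the whole organism (strain Swiss albino) with Mus musculus as the target, in the maximal electroshock model, with a stated time of 4 h (on this read-out higher numbers stand for an effect only at larger amounts of compound and lower numbers for an effect already at smaller amounts), compound 1 gives 300 mg/kg and compound 2 gives 300 mg/kg. Compound 2 thus stands level with compound 1 at the digits shown: the step of no change at the digits printed from compound 1 to compound 2 (within the scatter), hydrogen in place of hydroxy on an aromatic carbon, left the read-out unchanged within the scatter.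

Compound 3 `O=C(N/N=C\c1ccc(O)cc1)Nc1nnc(COc2ccc3ccccc3c2)o1` differs from compound 2 by hydroxy in place of hydrogen on an aromatic carbon. For the measured compounds named here, the one measured step that concerns a hydroxy on an aromatic carbon of this ring is no change at the digits printed from compound 1 to compound 2 (within the scatter), and it produced nothing beyond the scatter. Going by the values given here, since only that step is available, and it was flat, no shift beyond the scatter is expected in this assay for the new hydroxy; the expected step is no change at the digits printed from compound 2 to compound 3 (within the scatter). Compound 3 is therefore estimated to give 300 mg/kg, with a range from 150 mg/kg to 600 mg/kg.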

Compound 3, minimum effective dose: 300 mg/kg
For compound 3 middle estimate and measured number coincide at the digits printed; low and high end bracket the measured number.
By their numbers in this assay, from the lowest: compounds 1, 2 and 3 (each within the scatter of the next).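

In this assay, adding a hydroxy to the phenyl ring now has a second measured outcome, this time with the hydroxy placed para to a large group (no change at the digits printed from compound 2 to compound 3 (within the scatter)). The earlier compounds shown here could not show how the two hydroxy compounds compare, and the 3-hydroxyphenyl to 4-hydroxyphenyl exchange is flat as well (no change at the digits printed from compound 1 to compound 3 (within the scatter)). Among these three compounds, then, neither the presence of the hydroxy nor the choice between these two places separates the read-outs.

On these data alone, whether a different group on this ring, such as an amine, a carboxylic acid or a methoxy, would shift the minimum effective dose remains open. So does the effect of any change elsewhere in the shared core, since all three compounds carry it unaltered. Nothing measured here offers an explanation for the flat read-out.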